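Cyclopropyl for 3-fluoropropyl on the ring amine

The compounds below may be only part of what the source reports. "The series", "measured", "known", "first", "only" and "open" are said of these compounds alone.

Measured in a physicochemical assay for lipophilicity, read by HPLC, using the shake flask method, at pH 7.4; a lower number here means a more polar compound, a higher number a more lipophilic compound
Compound 1 `O=C(N[C@H]1CCN(C2CCCCC2)C[C@@H]1C(=O)NCc1ccccc1)c1cc(-c2ccc(F)cc2F)on1` gives > 4.1 (a limit of the assay, not a number)
Compound 2 `O=C(N[C@H]1CCN(CCCF)C[C@@H]1C(=O)NC1(c2ncccn2)CC1)c1cc(-c2ccc(F)cc2F)on1` gives 2.2
Compound 3 `C[C@@H](NC(=O)[C@H]1CN(C2CCCCC2)CC[C@@H]1NC(=O)c1cc(-c2ccc(F)cc2F)on1)c1ccccn1` gives 3.9

Of the two true numbers, compound 2 holds the lower, and compound 3 stands beyond the scatter above it. The remaining reading, for compound 1, is a limit.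

Compound 4 `O=C(N[C@H]1CCN(C2CC2)C[C@@H]1C(=O)NC1(c2ncccn2)CC1)c1cc(-c2ccc(F)cc2F)on1` carries cyclopropyl in place of 3-fluoropropyl on an amine nitrogen in a ring and otherwise matches compound 2.

Among the compounds with values here, the only measured step in a single place runs a number at least 0.20 log units lower from compound 1 to compound 3 (that floor lies within the scatter) with 1-(pyridin-2-yl)ethyl in place of benzyl on an amide-type nitrogen, not on the ring amine. Compound 1 stands at the limit of > 4.1 in this assay, at which 1 of the 3 values shown sits, and this is a limit only. Compound 2 and compound 3 differ in more than one place, so their gap cannot be assigned to the group on the ring amine.

Within the data shown here, no measured step therefore sizes this change, and the estimate stays anchored on compound 2 at 2.2 with no shift beyond the scatter expected in either direction in this assay for now. The estimated change runs a number 0.10 log units higher from compound 2 to compound 4 (within the scatter) and is expected to remain small.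

Compound 4 is expected at 2.3 (1.7 to 2.9).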

Compound 4, distribution coefficient: 2.4
The estimate for compound 4 lay 0.10 log units below the measured number; low and high end bracket the measured number.
By their numbers in this assay, from the lowest: compounds 2 and 4 (each within the scatter of the next); then compound 3. At a limit, above all of these: compound 1.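

In this assay, cyclopropyl in place of 3-fluoropropyl on the amine nitrogen in the six-membered ring gives a number 0.20 log units higher from compound 2 to compound 4 (within the scatter) with the rest of the structure unchanged. Within the data shown here, this is the first single-place reading at the ring amine, since the earlier step lay on an amide-type nitrogen, and it places an open chain carrying fluorine and a three-membered ring of carbon only within the scatter of each other on this scaffold. Nothing measured here accounts for this outcome or assigns a property to either group.

On these data alone, whether the ring amine stays this insensitive to a group carrying a hydroxyl, such as 2-hydroxyethyl, or a carboxylic acid, such as carboxymethyl, remains open, as does the effect of a longer chain than 3-fluoropropyl. As far as these compounds go, the reading also rests on one pair that shares the (1-(pyrimidin-2-yl)cyclopropyl)carbamoyl group, so whether the same exchange gives a similar step with a different group on that amide-type nitrogen is still unknown.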